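The compounds below may be only part of what the source reports. "The series", "measured", "known", "first", "only" and "open" are said of these compounds alone.

Working notes on the amide series sharing the core of compound 1.

Compound 1 `COc1ccc2c(=O)c(/C=C/C(=O)Nc3ccccc3)coc2c1` is the parent anilide. In an ADME assay on HepG2 2.2.15 cells (Homo sapiens) for cytotoxicity, read by MTT assay, with stated times of 48 h and 9 days (on this read-out lower numbers stand for higher toxicity in this test and higher numbers for lower toxicity in this test), compound 1 gives 523000 nM. Two measured neighbours differ from it only on the amide-type nitrogen: compound 2 `COc1ccc2c(=O)c(/C=C/C(=O)Nc3cc(C)ccc3C)coc2c1` gives 1100000 nM and compound 3 `COc1ccc2c(=O)c(/C=C/C(=O)NCc3ccccc3F)coc2c1` gives 146000 nM. Among these three numbers compound 1 holds the second highest place: its nearest neighbour is compound 2, with a 2.1-fold higher number from compound 1 to compound 2 (0.32 log units; beyond the scatter), and its furthest is compound 3, with a 3.6-fold lower number from compound 1 to compound 3 (0.55 log units; beyond the scatter). Between the two neighbours the gap is wider still, a 7.5-fold lower number from compound 2 to compound 3 (0.88 log units; beyond the scatter).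

Compound 4 `COc1ccc2c(=O)c(/C=C/C(=O)NCc3ccc(F)cc3F)coc2c1` is not yet measured. It differs from compound 1 in one place: 2,4-difluorobenzyl in place of phenyl on an amide-type nitrogen.

For the measured compounds named here, of the measured steps, the one from compound 1 to compound 3 bears most directly on this change, since both replace phenyl with a fluorinated benzyl on the amide-type nitrogen and that step was a modest lowering, a 3.6-fold lower number from compound 1 to compound 3 (0.55 log units; beyond the scatter). The step from compound 1 to compound 2 points the other way, but it moves toward a substituted anilide rather than a benzyl and is judged less relevant. For compound 4 a modest downward step of about a 4.4-fold lower number from compound 1 to compound 4 (0.64 log units; beyond the scatter) is therefore expected, beyond the scatter. The estimate for compound 4 in this assay is 120000 nM, with an expected range from 40000 nM to 400000 nM.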

Compound 4, half-maximal cytotoxic concentration: 79300 nM
Compound 4: the middle estimate sits 1.5-fold (0.18 log units) above what was measured; measured number inside the range.
By their numbers in this assay, from the lowest: compounds 4 and 3 (each within the scatter of the next); then compound 1; then compound 2.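

In this assay the 2,4-difluorobenzyl group on the amide-type nitrogen continues the downward direction first seen with 2-fluorobenzyl (a 6.6-fold lower number from compound 1 to compound 4 (0.82 log units; beyond the scatter)), and it opens the widest gap in the series against the 2,5-dimethylphenyl anilide (a 14-fold lower number from compound 2 to compound 4 (1.14 log units; beyond the scatter)). The second fluoro does not separate the two benzyl amides (a 1.8-fold lower number from compound 3 to compound 4 (0.27 log units; within the scatter)), so at this position the two fluorinated benzyl groups read as a single level, with both anilides, compound 1 and compound 2, standing clearly higher and no compound shown going against that split. Nothing at hand gives a measured reason for these differences.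

The compounds shown leave open whether the lower numbers belong to the benzyl itself or to its fluoro substituents, a question that an unsubstituted benzyl on the same nitrogen would settle. Also open, going by these compounds, is how far this read-out moves with a longer chain such as phenethyl, or with a benzyl carrying an amine or a carboxylic acid in place of fluoro.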